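Halogen exchange on the thiourea aryl of the shared core

This account rests on a few compounds, and the source may have more. Where it says the series, first, only, none or still open, it means among the compounds named here.

In a functional assay on HeLa cells (Homo sapiens) for antiproliferative activity, with a stated time of 24 h (on this read-out higher numbers stand for weaker inhibition and lower numbers for stronger inhibition), compound 2 `NC(=O)c1c(NC(=O)c2ccccc2Br)sc2c1CCN(C(=S)Nc1ccccc1Cl)C2` gives 46900 nM. Compound 2 carries the highest of the two numbers obtained; the nearest is compound 1 `NC(=O)c1c(NC(=O)c2ccccc2Cl)sc2c1CCN(C(=S)Nc1ccccc1Br)C2`, which in this assay gives 24600 nM, a gap that lies within the usual scatter, so no order between the two is claimed. Compound 3 `COc1ccccc1C(=O)Nc1sc2c(c1C(N)=O)CCN(C(=S)Nc1ccccc1Cl)C2` reports > 50000 nM, which is a limit of the assay and not a number. That value is the limit of > 50000 nM in this assay, at which 1 of the 3 values shown sits.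

Compound 4 `NC(=O)c1c(NC(=O)c2ccccc2Br)sc2c1CCN(C(=S)Nc1ccccc1Br)C2` differs from compound 2 by bromo in place of chloro on an aromatic carbon. Among the measured compounds shown here, only one measured step is available, an at least 1.0-fold higher number from compound 2 to compound 3 (0.02 log units; that floor lies within the scatter), and it concerns a different group on a different part of the molecule, so it speaks to the halogen exchange only indirectly. Compounds 1 and 2, which swap the places of bromo and chloro between the two aryl rings, show values within the scatter of each other, which gives no sign that the identity of the halogen on the thiourea aryl moves the number. Compound 4 is therefore expected to sit close to compound 2, with a 1.5-fold lower number from compound 2 to compound 4 (0.17 log units; within the scatter) not reaching beyond the scatter. Compound 4 is estimated at 32000 nM, within a range from 12000 nM to 60000 nM.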

Compound 4, half-maximal inhibitory concentration: 24700 nM
Compound 4: the middle estimate sits 1.3-fold (0.11 log units) above what was measured; the measured number falls inside the stated range.
By their numbers in this assay, from the lowest: compounds 1, 4 and 2 (each within the scatter of the next). At a limit, above all of these: compound 3.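

Compound 4 separates the two halogen exchanges, which the swap between compound 1 and compound 2 had changed together. In this assay, bromo in place of chloro on the thiourea aryl, with the 2-bromophenyl on the amide side held fixed, gives a 1.9-fold lower number from compound 2 to compound 4 (0.28 log units; within the scatter), and the same exchange on the amide aryl, with the 2-bromophenyl on the thiourea held fixed, gives a 1.0-fold higher number from compound 1 to compound 4 (0.00 log units; within the scatter). Each single exchange therefore stays within the scatter, so neither aryl ring shows a measurable preference between chloro and bromo in this small set, and nothing shown accounts for the size of either step.

Going by these compounds, whether an amine, a hydroxyl or a carboxylic acid in place of the halogen on the 2-bromophenyl of the thiourea would move the number beyond the scatter remains open, as does the effect of fluoro or of plain hydrogen at that place. On these data alone, compound 3 stands at > 50000 nM, which is a limit of the assay and not a number, so the size of the methoxy exchange on the amide aryl also remains open.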